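This account rests on a few compounds, and the source may have more. Where it says the series, first, only, none or still open, it means among the compounds named here.

In a functional assay on UACC-62 cells (Homo sapiens) (a higher number here means a weaker inhibitor of growth, a lower number a stronger inhibitor of growth), compound 1 `O=S(=O)(/C=C/c1ccc(F)cc1)Cc1ccc(Nc2ncnc3ccccc23)cc1` gives 5000 nM. Compound 2 `N#Cc1ccc(/C=C/S(=O)(=O)Cc2ccc(Nc3ncnc4ccccc34)cc2)cc1` reports only a limit, > 100000 nM. Compound 3 `O=S(=O)(/C=C/c1ccc(Br)cc1)Cc1ccc(Nc2ncnc3ccccc23)cc1` also reports only a limit, > 100000 nM, so it has no exact number. Compound 4 `O=S(=O)(/C=C/c1ccc(Cl)cc1Cl)Cc1ccc(Nc2ncnc3ccccc23)cc1` differs from compound 3 in one place: 2,4-dichlorophenyl in place of 4-bromophenyl on a double-bonded chain carbon bound to a double-bonded chain carbon. The closest measured steps are large: an at least 20-fold higher number from compound 1 to compound 2 (1.30 log units; beyond the scatter), with cyano in place of fluoro, and an at least 20-fold higher number from compound 1 to compound 3 (1.30 log units; beyond the scatter), with bromo in place of fluoro. In contrast, a step that the two limits leave unreadable from compound 2 to compound 3. None of these steps tests the entering group, so only a modest move toward a lower number is expected, and compound 4 may well stay at the limit. The expected step is an at least 2.5-fold lower number from compound 3 to compound 4 (0.39 log units; beyond the scatter). For compound 4, the estimated value is 40000 nM, with an expected range of 5000 nM to 100000 nM.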

Compound 4, concentration for 50% growth inhibition: 2000 nM
For compound 4 the middle estimate is 20-fold (1.30 log units) above the measured one, and the stated range ends above it.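

Within the data shown here, until now, every change from compound 1 raised the number; here, for the first time, a new group on the double-bonded chain carbon lowers it, with a 2.5-fold lower number from compound 1 to compound 4 (0.40 log units; beyond the scatter) in this assay. The other two steps are large, an at least 50-fold lower number from compound 3 to compound 4 (1.69 log units; beyond the scatter) and an at least 50-fold lower number from compound 2 to compound 4 (1.69 log units; beyond the scatter), but each starts from a limit and not an exact number: the limit of > 100000 nM in this assay, at which 2 of the 4 values shown sit. So this position can give stronger growth inhibition as well as lose it.

Which of the two chlorines matters stays open. So does how a methoxy group or an amine on this ring would fare.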